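Benzyloxy to propoxy: working notes on compound 3

The source may hold more compounds than are shown below. What is called first, only, known or untested is meant among the compounds shown, and "the series" means these compounds.

Within the data shown here, in an ADME assay on KB cells (Homo sapiens) for cytotoxicity (on this read-out higher numbers stand for an effect only at larger amounts of compound and lower numbers for an effect already at smaller amounts), compound 1 `COc1cc2c(c(OCc3ccccc3)c1OC)C(=O)[C@]1(OC)C=C[C@H]2N(C(=O)OCC(C)C)N1C(=O)OCC(C)C` gives 94 ug/mL as the only true number so far. Compound 2 `CCCOc1c(OC)c(OC)cc2c1C(=O)[C@]1(OC)C=C[C@H]2N(C(=O)OCC)N1C(=O)OCC` gives > 300 ug/mL in this read-out, and that value is a limit of the assay, not a number.

Compound 3 `CCCOc1c(OC)c(OC)cc2c1C(=O)[C@]1(OC)C=C[C@H]2N(C(=O)OCC(C)C)N1C(=O)OCC(C)C` keeps the rest of compound 1 and changes one place, with ethyl in place of phenyl on a saturated chain carbon bound to an oxygen on an aromatic ring so that benzyloxy becomes propoxy. Among the measured compounds shown here, no measured step isolates this change, so its size in this assay cannot be read directly from the data. A modest upward move is expected, meaning cytotoxicity only at somewhat larger amounts of compound. For the measured compounds named here, that lean rests on compound 2 with its > 300 ug/mL as the one other reading, and it remains a weak guide. The expected size is a 1.5-fold higher number from compound 1 to compound 3 (0.17 log units; within the scatter) on this estimate. For compound 3 the estimate is 140 ug/mL with an expected range of 50 ug/mL to 300 ug/mL in this assay.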

Compound 3, concentration for half-maximal effect: 299 ug/mL
Beside the measured number, compound 3's estimate is 2.1-fold (0.33 log units) below it, and the stated range covers the measured number.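

In this assay, among these compounds, the change from benzyloxy to propoxy gives a 3.2-fold higher number from compound 1 to compound 3 (0.50 log units; beyond the scatter), the first step that can be read as a number, and it shows that this place on the shared core responds to the change. With phenyl leaving and ethyl entering on a saturated chain carbon bound to an oxygen on an aromatic ring, cytotoxicity moves to larger amounts of compound, although this rests on a single pair and claims no pattern beyond compound 1 and compound 3. Little room remains for any further upward step at this place, since compound 3 already reads close to the ceiling of the read-out: the limit of > 300 ug/mL in this assay, at which 1 of the 3 values shown sits.

Going by these compounds, whether the step follows from losing the aromatic ring or from the shorter chain stays open, and a cyclohexyl group in place of phenyl would separate the two. Also open, on these data alone, is how a longer chain such as hexyloxy, or an amine or a carboxylic acid at the end of the propoxy chain, would read in this assay.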